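From 3,5-dimethoxyphenyl to 3-aminophenyl in compound 4

This account rests on a few compounds, and the source may have more. Where it says the series, first, only, none or still open, it means among the compounds named here.

In a functional assay on HL-60 cells (Homo sapiens) for cytotoxicity, read by MTT assay, with a stated time of 72 h (on this read-out lower numbers stand for stronger inhibition and higher numbers for weaker inhibition), compound 3 `COc1cc(Nc2nc3ccccc3nc2S(=O)(=O)c2ccc(Br)cc2)cc(OC)c1` gives 2540 nM as its result. That number lies beyond the usual scatter above that of compound 1 `Cc1ccc(S(=O)(=O)c2nc3ccccc3nc2Nc2cccc(N)c2)cc1` and within the scatter of that of compound 2 `COc1ccc(S(=O)(=O)c2nc3ccccc3nc2Nc2cccc(N)c2)cc1`. Compound 4 `Nc1cccc(Nc2nc3ccccc3nc2S(=O)(=O)c2ccc(Br)cc2)c1` has 3-aminophenyl in place of 3,5-dimethoxyphenyl on a nitrogen on an aromatic ring and is otherwise unchanged. For the measured compounds named here, the one measured step, a 1.4-fold higher number from compound 1 to compound 2 (0.14 log units; within the scatter), swaps methyl for methoxy and so does not test this change. However, compound 1, at 1080 nM, and compound 2, at 1490 nM, both already carry 3-aminophenyl. A small move to a lower number is therefore expected, and the estimated step is a 2.0-fold lower number from compound 3 to compound 4 (0.29 log units; within the scatter) in this assay. For compound 4 the estimated value is 1300 nM, with an expected range of 600 nM to 2800 nM.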

Compound 4, half-maximal inhibitory concentration: 1370 nM
Estimate against measurement, compound 4: 1.1-fold (0.02 log units) below, within the range that was stated.
By their numbers in this assay, from the lowest: compounds 1, 4, 2 and 3 (each within the scatter of the next, the first and the last beyond it).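

With bromo held in place, a direct test of this nitrogen substituent gives a step within the scatter (a 1.9-fold lower number from compound 3 to compound 4 (0.27 log units; within the scatter)), so 3-aminophenyl and 3,5-dimethoxyphenyl cannot be told apart here. With 3-aminophenyl held in place, bromo on the aromatic carbon also cannot be told apart from methoxy (a 1.1-fold lower number from compound 2 to compound 4 (0.04 log units; within the scatter)) or methyl (a 1.3-fold higher number from compound 1 to compound 4 (0.10 log units; within the scatter)), as both steps lie within the scatter. No evidence is available that bears on these results. As far as these compounds go, whether a carboxylic acid or a longer chain in place of the aromatic ring on this nitrogen would move the number beyond the scatter remains open.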